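Chain length at the carbamoyl(hydroxy)amino carbon: compound 4

This account rests on a few compounds, and the source may have more. Where it says the series, first, only, none or still open, it means among the compounds named here.

Measured so far in an assay for inhibition of Polyunsaturated fatty acid 5-lipoxygenase (Homo sapiens), read by HPLC, with stated times of 15 min and 10 min; on this read-out higher numbers stand for weaker inhibition and lower numbers for stronger inhibition:
- compound 1, `CC(C#Cc1cccc(C(=O)NCc2ccc(F)cc2C(F)(F)F)c1)N(O)C(N)=O`: 1300 nM
- compound 2, `CCC(C#Cc1cccc(C(=O)NCc2ccccc2C(F)(F)F)c1)N(O)C(N)=O`: 500 nM
- compound 3, `CCCC(C#Cc1cccc(C(=O)NCc2ccccc2C(F)(F)F)c1)N(O)C(N)=O`: 300 nM

Compound 3 gives the lowest number of the three in this assay. Its nearest neighbour is compound 2, and the step of a 1.7-fold lower number from compound 2 to compound 3 (0.22 log units; within the scatter) stays within the scatter, so the two cannot be ranked. Compound 1 stands furthest off, beyond the scatter, but compound 1 also carries a fluorine on the benzyl ring, so its gap to compound 3 is not a single change.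

Compound 4, `CC(C#Cc1cccc(C(=O)NCc2ccccc2C(F)(F)F)c1)N(O)C(N)=O`, is not yet measured. It differs from compound 3 by hydrogen in place of ethyl on a saturated chain carbon, two bonds along the chain from an amide-type nitrogen and a triple-bonded carbon; read one bond further out, the side chain goes from propyl to methyl, that is from 1-(carbamoyl(hydroxy)amino)butyl to 1-(carbamoyl(hydroxy)amino)ethyl.

For the measured compounds named here, the only measured step that bears on this is a 1.7-fold lower number from compound 2 to compound 3 (0.22 log units; within the scatter), where lengthening the same chain by one carbon lowered the number, though only within the scatter. Compound 4 removes two carbons in the opposite direction, so the expected move is toward a higher number. Compound 4 is therefore expected to give about 800 nM in this assay, with a range of 400 nM to 1800 nM. The expected step of a 2.7-fold higher number from compound 3 to compound 4 (0.43 log units; beyond the scatter) would be modest and may still fall within the scatter.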

Compound 4, half-maximal inhibitory concentration: 700 nM
Estimate against measurement, compound 4: 1.1-fold (0.06 log units) above; the measured number falls inside the stated range.
By their numbers in this assay, from the lowest: compounds 3, 2, 4 and 1 (each within the scatter of the next, the first and the last beyond it).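

Working notes on the side chain at the carbamoyl(hydroxy)amino carbon, in this assay: the full shortening from 1-(carbamoyl(hydroxy)amino)butyl to 1-(carbamoyl(hydroxy)amino)ethyl gives a 2.3-fold higher number from compound 3 to compound 4 (0.37 log units; beyond the scatter) and is the first single-place chain change to clear the scatter, though only modestly. The intermediate step, a 1.4-fold higher number from compound 2 to compound 4 (0.15 log units; within the scatter), stays within the scatter, as does a 1.7-fold lower number from compound 2 to compound 3 (0.22 log units; within the scatter), so only the propyl and methyl side chains can be ranked, and no single-carbon change can be. With the methyl side chain in place, a 1.9-fold lower number from compound 1 to compound 4 (0.27 log units; within the scatter) also stays within the scatter, so the hydrogen and fluoro forms on that aromatic carbon cannot be ranked, and nothing available accounts for the chain-length difference.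

Still open, from the compounds shown here alone, is whether the number keeps falling with a butyl or longer straight chain on this carbon, and how a branched isopropyl or a cyclopropyl group would compare with propyl. Also open, going by these compounds, is how fluoro in place of hydrogen on the aromatic carbon reads when the side chain is propyl rather than methyl.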